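This account rests on a few compounds, and the source may have more. Where it says the series, first, only, none or still open, it means among the compounds named here.

Measured in an ADME assay (liver) for metabolic stability, with Liver microsome (Rattus norvegicus) as the target, using microsomes and NADPH, with a stated time of 30 min, tested at 1 uM; a higher number here means faster removal of the compound, a lower number slower removal
- compound 1 `Nc1ccc(S(=O)(=O)N2CCN(c3ncc(C(O)(C(F)(F)F)C(F)(F)F)cc3-c3cccc(F)c3)CC2)cn1` with 52 mL.min-1.g-1
- compound 2 `CS(=O)(=O)Nc1cccc(-c2cc(C(O)(C(F)(F)F)C(F)(F)F)cnc2N2CCN(S(=O)(=O)c3ccc(N)nc3)CC2)c1` with 81 mL.min-1.g-1

Compound 2 at 81 mL.min-1.g-1 lies within the usual scatter of compound 1 at 52 mL.min-1.g-1 on these numbers. Compound 3 `Nc1ccc(S(=O)(=O)N2CCN(c3ncc(C(O)(C(F)(F)F)C(F)(F)F)cc3-c3cncc(F)c3)CC2)cn1` has not been measured yet, and it differs from compound 2 at one place: 5-fluoropyridin-3-yl in place of 3-(methanesulfonamido)phenyl on an aromatic carbon with 5-fluoropyridin-3-yl in place of 3-(methanesulfonamido)phenyl on an aromatic carbon. Among the measured compounds shown here, only one measured step bears on this: a 1.6-fold higher number from compound 1 to compound 2 (0.19 log units; within the scatter) with methanesulfonamido in place of fluoro on an aromatic carbon. Compound 3 loses that methanesulfonamido too, so a small move toward lower numbers is expected, with one step as thin support. The expected change is a 1.6-fold lower number from compound 2 to compound 3 (0.21 log units; within the scatter) and no larger than the scatter. In this assay compound 3 is estimated at 50 mL.min-1.g-1 with a likely range from 25 mL.min-1.g-1 to 90 mL.min-1.g-1 for repeated measurements.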

Compound 3, intrinsic clearance in microsomes: 19 mL.min-1.g-1
The estimate for compound 3 lay 2.6-fold (0.42 log units) above the measured number; measured number below the stated range.
By their numbers in this assay, from the lowest: compound 3; then compounds 1 and 2 (each within the scatter of the next).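

In this assay, among the compounds shown here, the 5-fluoropyridin-3-yl group in place of 3-(methanesulfonamido)phenyl gives a 4.3-fold lower number from compound 2 to compound 3 (0.63 log units; beyond the scatter) and so shows that a change at this position can move the number beyond the scatter, which the step between the earlier compounds did not show. For the compounds shown here, the closer comparison is a 2.7-fold lower number from compound 1 to compound 3 (0.44 log units; beyond the scatter) where 5-fluoropyridin-3-yl replaces 3-fluorophenyl, so that with the fluorine kept, a ring nitrogen in place of a ring carbon is the only change and is enough to give a step beyond the scatter. Nothing measured here explains why the number falls.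

On these data alone, whether the fluorine still matters on the pyridine ring stays open, since a pyridin-3-yl group without it, or with a nitrile or methoxy group instead, would be needed to tell. Also open, as far as these compounds go, is how a pyrimidin-5-yl group, with a second ring nitrogen, would behave at this position.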